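The compounds below may be only part of what the source reports. "The series", "measured", "known", "first", "only" and "open" are said of these compounds alone.

Compound 1 `O=C(NCCC1CC1)c1ccc(N2CCC(Oc3ccccc3C(F)(F)F)CC2)nn1` gives 14 nM in an assay on microsomes from liver for inhibition of acyl-CoA desaturase 1 (Rattus norvegicus); a lower number here means a stronger inhibitor, a higher number a weaker inhibitor.
Compound 2 `Cc1ccccc1OC1CCN(c2ccc(-n3ccnc3)nn2)CC1` gives 39 nM in this assay.
Compound 3 `Cc1ccc(OC2CCN(c3ccc(-n4ccnc4)nn3)CC2)cc1` gives 527 nM in this assay.

Among these three numbers, compound 2 stands in the middle: compound 1 gives the lowest number and compound 3 the highest, and the gap from compound 2 to each of them lies beyond the scatter. Compound 4 `Cc1cccc(OC2CCN(c3ccc(-n4ccnc4)nn3)CC2)c1` has not yet been measured. It differs from compound 2 in one place: 3-methylphenyl in place of 2-methylphenyl on an oxygen on a saturated carbon. Among the compounds with values here, only one measured step bears on this change, the one in which the methyl group on the same phenyl ring was moved to give compound 3: a 14-fold higher number from compound 2 to compound 3 (1.13 log units; beyond the scatter). That step weakened inhibition by a large margin. Within the data shown here, since compound 4 also moves the methyl group on that ring, a weakening is expected here as well, though the single comparison gives no firm size, so the expected step is a 3.8-fold higher number from compound 2 to compound 4 (0.59 log units; beyond the scatter). The estimate for compound 4 in this assay is 150 nM, expected to fall between 50 nM and 450 nM.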

Compound 4, half-maximal inhibitory concentration: 251 nM
Beside the measured number, compound 4's estimate is 1.7-fold (0.22 log units) below it; the measured number falls inside the stated range.
By their numbers in this assay, from the lowest: compound 1; then compound 2; then compound 4; then compound 3.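

In this assay, exchanging 2-methylphenyl for 3-methylphenyl gives a 6.4-fold higher number from compound 2 to compound 4 (0.81 log units; beyond the scatter), so the loss of inhibition seen with 4-methylphenyl is not confined to that one isomer: both isomers tested against compound 2 are weaker inhibitors. The two weaker isomers also differ from each other, with a 2.1-fold lower number from compound 3 to compound 4 (0.32 log units; beyond the scatter), which orders this small series as 2-methylphenyl, then 3-methylphenyl, then 4-methylphenyl, from strongest to weakest inhibitor. Nothing available explains why moving one methyl group around the ring changes inhibition this much.

Still open, on these data alone, is whether a chlorine atom, a methoxy group or a nitrile on this ring would follow the same order as methyl. A plain phenyl with no methyl group would show whether 2-methylphenyl improves inhibition or the other two isomers reduce it.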